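Swapping fluoro for methoxy: what to expect for compound 3

A few compounds are considered here, and "the series" means these few. Any claim that something is new, unique, unknown or untested is made for them only; others in the source may bear on it.

compound 1 `COc1ccc(-c2nn(-c3ccccc3)cc2C(=O)Nc2nc3ccccc3s2)cc1`: 13700 nM
compound 2 `COc1ccc(-c2nn(-c3ccccc3)cc2C(=O)Nc2nc3ccc(F)cc3s2)cc1`: 7560 nM

In a functional assay on A549 cells (Homo sapiens) for cytotoxicity, read by MTT assay, with a stated time of 72 h (a lower number here means a stronger inhibitor, a higher number a weaker inhibitor), compound 1 gives 13700 nM and compound 2 gives 7560 nM. Compound 2 holds the lower of these two numbers, but the step of a 1.8-fold lower number from compound 1 to compound 2 (0.26 log units; within the scatter) is too small to count as a real difference. Compound 3 `COc1ccc(-c2nn(-c3ccccc3)cc2C(=O)Nc2nc3ccc(OC)cc3s2)cc1` differs from compound 2 by methoxy in place of fluoro on an aromatic carbon. Among the compounds with values here, the one measured step, fluoro in place of hydrogen at that same carbon, stayed within the scatter, and no measured step shows a methoxy there. Compound 3 is therefore expected to change little, a 1.1-fold higher number from compound 2 to compound 3 (0.02 log units; within the scatter), with an estimate of 8000 nM and a range from 3000 nM to 25000 nM.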

Compound 3, half-maximal inhibitory concentration: 18900 nM
Compound 3: the middle estimate sits 2.4-fold (0.37 log units) below what was measured; the range from low to high includes it.
By their numbers in this assay, from the lowest: compounds 2, 1 and 3 (each within the scatter of the next, the first and the last beyond it).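

This aromatic carbon does respond to its substituent. In this assay, within the data shown here, swapping fluoro for methoxy gives the first step in this set beyond the scatter, though a modest one (a 2.5-fold higher number from compound 2 to compound 3 (0.40 log units; beyond the scatter)). Methoxy still cannot be told apart from hydrogen (a 1.4-fold higher number from compound 1 to compound 3 (0.14 log units; within the scatter)), so the readable gap lies only between the fluoro and methoxy compounds, and no supporting measurement accounts for it. From the compounds shown here alone, whether an amine or a carboxylic acid at this carbon would shift the number further remains open. So does whether the same gap would appear with these groups elsewhere on the core.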